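Methoxy in place of hydrogen on compound 3

The compounds below may be only part of what the source reports. "The series", "measured", "known", "first", "only" and "open" are said of these compounds alone.

For the measured compounds named here, the series so far holds compound 1 `c1ccc2c(c1)CCC2CCCN1CCN(c2cccc3c2OCCO3)CC1`, compound 2 `c1ccc2c(c1)CCCCC2CCN1CCN(c2cccc3c2OCCO3)CC1` and compound 3 `COc1ccc2c(c1)C(CCN1CCN(c3cccc4c3OCCO4)CC1)C2`. In a functional assay on the whole organism for antagonist activity, with Rattus norvegicus as the target (on this read-out lower numbers stand for an effect already at smaller amounts and higher numbers for an effect only at larger amounts of compound), compound 1 gives 0.29 mg/kg and compound 2 gives 4.26 mg/kg. Compound 3 gives 0.48 mg/kg, which lies within the scatter of compound 1, while the number for compound 2 is higher by more than the scatter.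

The next structure is compound 4 `COc1cc2c(cc1OC)C(CCN1CCN(c3cccc4c3OCCO4)CC1)C2`, which differs from compound 3 by a single change: methoxy in place of hydrogen on an aromatic carbon. This is methoxy in place of hydrogen on an aromatic carbon, ortho to a methoxy group, meta to a fused ring and para to a fused ring.

Going by the values given here, no pair of measured compounds differs in one place only, so the data give no direct guide to the size of this step. Compound 2 at 4.26 mg/kg shows that numbers in this series can lie far apart, so the range is kept wide. No step beyond the scatter is expected, with only a weak lean toward a higher number. The expected change in this assay is a 1.3-fold higher number from compound 3 to compound 4 (0.10 log units; within the scatter), an estimate that stays within the scatter. For compound 4 the estimated value is 0.6 mg/kg, with an expected range from 0.2 mg/kg to 1.8 mg/kg.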

Compound 4, dose for 50% inhibition: 1.41 mg/kg
Beside the measured number, compound 4's estimate is 2.4-fold (0.37 log units) below it, within the range that was stated.
By their numbers in this assay, from the lowest: compounds 1 and 3 (each within the scatter of the next); then compound 4; then compound 2.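

In this assay, for the compounds shown here, the carbon ortho to a methoxy group, meta to a fused ring and para to a fused ring is not a neutral place for substitution: methoxy in place of hydrogen gives a 2.9-fold higher number from compound 3 to compound 4 (0.47 log units; beyond the scatter) and so provides the first single-place comparison. The shift goes toward an effect only at larger amounts of compound, showing that one added methoxy on the aromatic ring of compound 3 can move the read-out beyond the usual scatter, although this rests on a single modest step on one background. The information available offers no account of what lies behind this step.

On these data alone, whether the step is specific to methoxy or would also follow from another group at this carbon remains open, and a fluorine atom, a chlorine atom, a hydroxy group or the longer ethoxy group there would help to separate these cases. Also open, as far as these compounds go, is whether the same step would appear on the core of compound 1 or compound 2, or with the existing methoxy of compound 3 replaced by hydrogen.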